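The compounds below may be only part of what the source reports. "The series", "measured", "known", "first", "only" and "open" are said of these compounds alone.

Compound 1 `Cc1cc(=O)oc2cc(SCc3ccccn3)ccc12` reaches only a limit in a functional assay on DU-145 cells (Homo sapiens) for antiproliferative activity, read by sulforhodamine B assay, with a stated time of 72 h (on this read-out lower numbers stand for stronger inhibition of growth and higher numbers for weaker inhibition of growth), namely > 35200 nM. Compound 2 `Cc1cc(=O)oc2cc(SCc3cccc(C#N)c3)ccc12` likewise yields only a limit in this assay, > 32500 nM, so compound 2 stands at one of the two limits shown and at no number. Compound 3 `Cc1cc(=O)oc2cc(SCc3cccc(OC(F)(F)F)c3)ccc12` remains to be measured in this assay; it differs from compound 2 by trifluoromethoxy in place of cyano on an aromatic carbon. For the measured compounds named here, with both known values at limits, no measured step sets the size of this change, and no step beyond the scatter is expected. Compound 3 is estimated at 40000 nM in this assay, within 15000 nM to 110000 nM. The expected step is a step that the limit leaves unreadable from compound 2 to compound 3.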

Compound 3, concentration for 50% growth inhibition: 15500 nM
For compound 3 the middle estimate is 2.6-fold (0.41 log units) above the measured one, and the stated range covers the measured number.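

With compound 3, this position yields a measured number rather than a limit in this assay, showing that growth inhibition can be read in this series of thioethers. Trifluoromethoxy in place of cyano on this aromatic carbon gives an at least 2.0-fold lower number from compound 2 to compound 3 (0.32 log units; beyond the scatter). That step has only a lower bound, and its full size cannot be read, as one end of it is a limit: the limit of > 32500 nM in this assay, at which 1 of the 3 values shown sits.

The compounds shown leave open whether an amine or a carboxylic acid on this carbon would lower the number further. They also leave open whether trifluoromethoxy would give a similar step at another carbon of that ring.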